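The source may report more compounds than this note shows. Statements on the series, on what has been measured and on what is new or still open speak of the compounds shown alone.

Compound 1 `CC1(C)O[C@H]([C@H]2COC(C)(C)O2)[C@@H](C2CC(=O)SS2)O1` and compound 2 `CC1(C)O[C@H]([C@H]2COC(C)(C)O2)[C@@H](C2CC(=O)S[S+]2[O-])O1` share one core, while compound 3 `Cc1cn([C@H]2C[C@H](O)[C@@H](C3CC(=O)SS3)O2)c(=O)[nH]c1=O` is built on another; the difference between the two cores is not broken down here. In a functional assay on HeLa cells (Homo sapiens) for cytotoxicity, read by MTT assay (a higher number here means a weaker inhibitor, a lower number a stronger inhibitor), compound 1 gives 35900 nM, compound 2 gives 18200 nM and compound 3 gives 299000 nM. The change from compound 1 to compound 2 is a group of 7 heavy atoms (3 carbon, 2 oxygen, 2 sulfur; one five-membered non-aromatic ring with 2 hetero atoms) in place of a group of 6 heavy atoms (3 carbon, 1 oxygen, 2 sulfur; one five-membered non-aromatic ring with 2 hetero atoms), on a saturated ring carbon, and it brought a 2.0-fold lower number from compound 1 to compound 2 (0.30 log units; within the scatter). Compound 4 `Cc1cn([C@H]2C[C@H](O)[C@@H](C3CC(=O)S[S+]3[O-])O2)c(=O)[nH]c1=O`, not yet measured, carries the same kind of change on the core of compound 3: a group of 7 heavy atoms (3 carbon, 2 oxygen, 2 sulfur; one five-membered non-aromatic ring with 2 hetero atoms) in place of a group of 6 heavy atoms (3 carbon, 1 oxygen, 2 sulfur; one five-membered non-aromatic ring with 2 hetero atoms), on a saturated ring carbon. The surroundings differ: in compound 1 the place is on a five-membered non-aromatic ring with 2 oxygen, next to the ring atom that bears a group of 7 heavy atoms, two ring bonds from the ring atom that bears two methyl groups; in compound 3 it is on a five-membered non-aromatic ring with 1 oxygen, next to the ring oxygen and next to the ring atom that bears a hydroxy group. Because a 2.0-fold lower number from compound 1 to compound 2 (0.30 log units; within the scatter) stayed within the scatter, a step of similar size is expected in this assay, a 1.8-fold lower number from compound 3 to compound 4 (0.25 log units; within the scatter), though it rests on a single pair. Compound 4 is therefore estimated at 170000 nM, between 60000 nM and 500000 nM.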

Compound 4, half-maximal inhibitory concentration: 119000 nM
Compound 4: the middle estimate sits 1.4-fold (0.15 log units) above what was measured; the measured number falls inside the stated range.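

In this assay, putting the group of 7 heavy atoms in place of the group of 6 heavy atoms on the core of compound 3 gave a 2.5-fold lower number from compound 3 to compound 4 (0.40 log units; beyond the scatter), a modest step in the same direction as the one seen on the other core. Set side by side, the two steps do not differ, so in this small series the change carried over from one core to the other with much the same size: the same change on two cores in this assay, a 2.0-fold lower number (0.30 log units; within the scatter) from compound 1 to compound 2 and a 2.5-fold lower number (0.40 log units; beyond the scatter) from compound 3 to compound 4, 1.3-fold (0.11 log units) apart, within the scatter of two such steps. Going by these compounds alone, this rests on only two pairs in a single assay, one of them within the scatter on its own, so it gives no rule for other cores and does not show why the number falls.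

The compounds shown leave open whether the change would behave alike on a core bearing an amine or a carboxylic acid in place of the hydroxy group. Also open, as far as these compounds go, is how a ring with nitrogen in place of one sulfur, or with two oxygens on the same sulfur, would compare.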